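Fluoro for Isopropyl on an Amide-Linked Aromatic Ring

The source may hold more compounds than are shown below. What is called first, only, known or untested is meant among the compounds shown, and "the series" means these compounds.

Of the compounds shown here, three sharing one core have been measured in an in vitro assay on BTI-TN-5B1-4 cells for inhibition of Amine oxidase [flavin-containing] B (Homo sapiens), read by fluorescence; on this read-out lower numbers stand for stronger inhibition and higher numbers for weaker inhibition. Compound 1 `O=C(NC1CCCCC1)c1cc2ccccc2oc1=O` gives 500 nM, compound 2 `CC(C)CNC(=O)c1cc2ccccc2oc1=O` gives 3270 nM, and compound 3 `CC(C)c1ccc(NC(=O)c2cc3ccccc3oc2=O)cc1` gives 650 nM. Among these numbers compound 3 holds the second highest value; it lies within the scatter of compound 1 and beyond the scatter from compound 2. For the measured compounds named here, the only single-place step measured, a 6.5-fold higher number from compound 1 to compound 2 (0.82 log units; beyond the scatter), swaps a group on the amide nitrogen. Compound 4 `O=C(Nc1ccc(F)cc1)c1cc2ccccc2oc1=O` differs from compound 3 by fluoro in place of isopropyl on an aromatic carbon. Going by the values given here, no measured step touches that aromatic ring, and the nitrogen swap offers no direct guide. The expected step is therefore a 1.1-fold higher number from compound 3 to compound 4 (0.03 log units; within the scatter), not beyond the scatter. Compound 4 is estimated at 700 nM in this assay, with a range from 250 nM to 2000 nM.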

Compound 4, half-maximal inhibitory concentration: 67 nM
Compound 4: the middle estimate sits 10-fold (1.02 log units) above what was measured, and the stated range ends above it.
By their numbers in this assay, from the lowest: compound 4; then compounds 1 and 3 (each within the scatter of the next); then compound 2.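

For the compounds shown here, replacing isopropyl with fluoro on the aromatic ring gives a 9.7-fold lower number from compound 3 to compound 4 (0.99 log units; beyond the scatter), so the group at this ring position, which no earlier step touched, can matter greatly. The aromatic ring alone does not bring the gain: 4-fluorophenyl on the amide nitrogen gives a 7.5-fold lower number from compound 1 to compound 4 (0.87 log units; beyond the scatter) and a 49-fold lower number from compound 2 to compound 4 (1.69 log units; beyond the scatter), yet compound 3, which also carries an aromatic ring there, lies within the scatter of compound 1. Nothing at hand explains why the swap helps. As far as these compounds go, whether chloro, methoxy or an amine at this position would match fluoro remains open.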